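A few compounds are considered here, and "the series" means these few. Any claim that something is new, unique, unknown or untested is made for them only; others in the source may bear on it.

For the measured compounds named here, in a physicochemical assay for solubility, in phosphate buffer, with a stated time of 18 h (a higher number here means a more soluble compound, a lower number a less soluble compound), compound 2 (`CC(C)(C)c1nc(-c2cccs2)c2c(N)c(C#N)c(N)nc2n1`) gives 56000 nM, the highest of the two numbers so far, and compound 1 (`CCCCc1nc(C(C)(C)C)nc2nc(N)c(C#N)c(N)c12`) gives 6000 nM. Compound 3 (`CC(C)(C)c1nc(-c2ccccc2)c2c(N)c(C#N)c(N)nc2n1`) differs from compound 2 by one change: phenyl in place of thiophen-2-yl on an aromatic carbon. Going by the values given here, the only measured step, a 9.3-fold higher number from compound 1 to compound 2 (0.97 log units; beyond the scatter), is modest and swaps butyl for thiophen-2-yl, the group now leaving. Among the compounds with values here, no measured step compares thiophen-2-yl with phenyl directly, so only a small drop in this assay is expected, possibly none beyond the scatter. The estimated step is a 1.6-fold lower number from compound 2 to compound 3 (0.20 log units; within the scatter). Compound 3 is expected at 35000 nM, with an estimated range of 12000 nM to 90000 nM.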

Compound 3, solubility: 4000 nM
The estimate for compound 3 lay 8.8-fold (0.94 log units) above the measured number, and the stated range ends above it.
By their numbers in this assay, from the lowest: compounds 3 and 1 (each within the scatter of the next); then compound 2.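

In this assay, a 14-fold lower number from compound 2 to compound 3 (1.15 log units; beyond the scatter) shows that the two aromatic rings are far from interchangeable on this carbon, next to the ring nitrogen. With a 1.5-fold lower number from compound 1 to compound 3 (0.18 log units; within the scatter) as the comparison, phenyl and butyl cannot be told apart here, so among these three groups only thiophen-2-yl stands out. No measurement at hand accounts for the thiophen-2-yl result.

Going by these compounds, whether the higher number is particular to thiophen-2-yl or extends to furan-2-yl or thiazol-2-yl remains open. On these data alone, the effect of an amine or a carboxylic acid on the phenyl ring is also open.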